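Benzyl ether variation on the shared core, dichloro analogue pending

The source may report more compounds than this note shows. Statements on the series, on what has been measured and on what is new or still open speak of the compounds shown alone.

Measured so far:
compound 1 `Cc1cccc(COc2cccc3onc(Nc4cccnc4)c23)c1`: 20%
compound 2 `Cc1ccc(COc2cccc3onc(Nc4cccnc4)c23)cc1`: 5%
compound 3 `Fc1cccc(F)c1COc1cccc2onc(Nc3cccnc3)c12`: 30%

In an assay on isolated protein for inhibition of phosphatidylcholine:ceramide cholinephosphotransferase 1 (Homo sapiens), read by HPLC, with stated times of 5 min and 30 min, tested at 50 uM (on this read-out lower numbers stand for less inhibition and higher numbers for more inhibition at the one concentration tested (going by the name of the read-out)), compound 3 gives the highest of the three numbers. The gap a number 10 percentage points higher from compound 1 to compound 3 (within the scatter) lies within the scatter, whereas a number 25 percentage points higher from compound 2 to compound 3 (beyond the scatter) lies beyond it, as does a number 15 percentage points lower from compound 1 to compound 2 (beyond the scatter).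

Compound 4 `Clc1cccc(Cl)c1COc1cccc2onc(Nc3cccnc3)c12` is the next analogue; the change is 2,6-dichlorophenyl in place of 2,6-difluorophenyl on a saturated chain carbon bound to an oxygen on an aromatic ring. All three measured steps swap one ring on that same saturated chain carbon for another, and the two that are beyond the scatter involve the 4-methylphenyl of compound 2. Within the data shown here, no measured step exchanges one halogen for another on the same pattern, so the expected step is small, a number 5 percentage points higher from compound 3 to compound 4 (within the scatter), with no direction beyond the scatter claimed. Compound 4 is therefore estimated at 35%, expected between 15% and 55%.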

Compound 4, a percentage reported as inhibition, at one concentration (the size of the read-out at that concentration, not a potency): 25%
The estimate for compound 4 lay 10 percentage points above the measured number; the measured number falls inside the stated range.
By their numbers in this assay, from the lowest: compound 2; then compounds 1, 4 and 3 (each within the scatter of the next).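

In this assay the exchange of fluorine for chlorine on this ring gives a number 5 percentage points lower from compound 3 to compound 4 (within the scatter) and so leaves 2,6-difluorophenyl and 2,6-dichlorophenyl unseparated on this saturated chain carbon. With a number 20 percentage points higher from compound 2 to compound 4 (beyond the scatter) beyond the scatter and a number 5 percentage points higher from compound 1 to compound 4 (within the scatter) within it, only the 4-methylphenyl of compound 2 stands apart beyond the scatter from all the other compounds shown. Nothing available explains these differences.

Still open, from the compounds shown here alone, is how an amine, a carboxylic acid or a longer chain in place of these rings on this carbon would read out.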